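A few compounds are considered here, and "the series" means these few. Any claim that something is new, unique, unknown or untested is made for them only; others in the source may bear on it.

Compound 1 `CCS(=O)(=O)Nc1ccc(NC(=O)c2ccc(C#N)cc2)cc1OC` gives 66400 nM in an ADME assay on RAW264.7 cells (Mus musculus) for cytotoxicity, read by MTT assay, with a stated time of 48 h; a higher number here means a weaker inhibitor, a lower number a stronger inhibitor.
Compound 2 `COc1cc(NC(=O)c2ccc(C#N)cc2)ccc1NS(=O)(=O)C(F)(F)F` returns a limit of the assay rather than a number, > 250000 nM, in this assay.
Compound 3 `CCS(=O)(=O)Nc1ccc(NC(=O)c2cccc(C(F)(F)F)c2)cc1Cl` gives 62400 nM in this assay.

Compound 1 and compound 2 share a core and differ by one change, (trifluoromethyl in place of ethyl on a sulfonyl sulfur). That change made a step of an at least 3.7-fold higher number from compound 1 to compound 2 (0.57 log units; beyond the scatter), whose size is known only as a bound because of the limit of > 250000 nM in this assay, at which 1 of the 3 values shown sits. Compound 4 `O=C(Nc1ccc(NS(=O)(=O)C(F)(F)F)c(Cl)c1)c1cccc(C(F)(F)F)c1` has not yet been measured; it stands to compound 3 as compound 2 stands to compound 1, by the same change, (trifluoromethyl in place of ethyl on a sulfonyl sulfur). How the core of compound 3 differs from the core of compound 1 is not broken down here. The values of compound 3 and compound 1 lie within the scatter of each other. For compound 4 a step of a 4.0-fold higher number from compound 3 to compound 4 (0.60 log units; beyond the scatter) is expected in this assay, of a size like the earlier one, resting on the step of an at least 3.7-fold higher number from compound 1 to compound 2 (0.57 log units; beyond the scatter). Compound 4 is therefore estimated at 250000 nM in this assay, and the result may again come out as a limit.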

Compound 4, half-maximal inhibitory concentration: 55800 nM
Estimate against measurement, compound 4: 4.5-fold (0.65 log units) above; the measured number lies below the stated range.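

In this assay, trifluoromethyl in place of ethyl on a sulfonyl sulfur gave a 1.1-fold lower number from compound 3 to compound 4 (0.05 log units; within the scatter), so on this core the change made no step beyond the scatter. The change therefore did not carry over from one core to the other as a step of like size: the same change on two cores in this assay, an at least 3.7-fold higher number (0.57 log units; beyond the scatter) from compound 1 to compound 2 and a 1.1-fold lower number (0.05 log units; within the scatter) from compound 3 to compound 4, at least 4.2-fold (0.62 log units) apart, beyond the scatter of two such steps. For the compounds shown here, with only one pair on each core, this does not show which difference between the cores goes with the gap, and the earlier step is known only as a bound: the limit of > 250000 nM in this assay, at which 1 of the 4 values shown sits.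

The compounds shown leave open how a methyl or a propyl chain on the sulfonyl sulfur would read in this assay on either core. Also open, from the compounds shown here alone, is what the same change would do on a third core, for instance one carrying an amine.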